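Changing the Pendant Aryl Group on a Shared Core

The compounds below may be only part of what the source reports. "The series", "measured", "known", "first", "only" and "open" are said of these compounds alone.

Of the compounds shown here, three built on one shared core have been tested in a functional assay on SGC-7901 cells (Homo sapiens) for antiproliferative activity, read by MTT assay, with a stated time of 72 h; a higher number here means a weaker inhibitor, a lower number a stronger inhibitor. Compound 1, `COc1cc(-n2cnc3ccc(-c4ccccc4Cl)cc32)cc(OC)c1OC`, carries a 2-chlorophenyl group, and in this assay compound 1 reaches only the limit of > 10000 nM, not a number. Compound 2, `COc1ccc(-c2ccc3ncn(-c4cc(OC)c(OC)c(OC)c4)c3c2)cc1O`, gives 44 nM in this assay, and compound 3, `COc1cc(-n2cnc3ccc(-c4ccc([N+](=O)[O-])cc4)cc32)cc(OC)c1OC`, gives 79 nM. Compound 3 therefore holds the higher of the two measured numbers, its nearest neighbour being compound 2, and that gap is a 1.8-fold higher number from compound 2 to compound 3 (0.25 log units; within the scatter), which lies within the scatter. The steps away from the 2-chlorophenyl compound are large: an at least 220-fold lower number from compound 1 to compound 2 (2.35 log units; beyond the scatter) and an at least 120-fold lower number from compound 1 to compound 3 (2.10 log units; beyond the scatter).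

Compound 4, `COc1cc(-n2cnc3ccc(-c4cccc(Cl)c4)cc32)cc(OC)c1OC`, is the next candidate. 3-chlorophenyl in place of 4-nitrophenyl on an aromatic carbon Two measured steps bear on this change: replacing the 2-chlorophenyl of compound 1 with 4-nitrophenyl gave an at least 120-fold lower number from compound 1 to compound 3 (2.10 log units; beyond the scatter), and with 3-hydroxy-4-methoxyphenyl gave an at least 220-fold lower number from compound 1 to compound 2 (2.35 log units; beyond the scatter). Among the compounds with values here, the only other chlorophenyl compound, compound 1, sits at the limit of > 10000 nM in this assay, at which 1 of the 3 values shown sits. Since compound 4 returns to a chlorophenyl group, though in a different position, part of that large gain is expected to be lost, and the number for compound 4 is expected to rise, a 25-fold higher number from compound 3 to compound 4 (1.40 log units; beyond the scatter), with wide uncertainty. Compound 4 is estimated to give 2000 nM, in a range from 300 nM to 10000 nM.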

Compound 4, half-maximal inhibitory concentration: 1490 nM
Estimate against measurement, compound 4: 1.3-fold (0.13 log units) above; low and high end bracket the measured number.
By their numbers in this assay, from the lowest: compounds 2 and 3 (each within the scatter of the next); then compound 4. At a limit, above all of these: compound 1.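

Compound 4 shows that a chlorophenyl group at this position does not by itself abolish activity in this assay, for 3-chlorophenyl in place of 2-chlorophenyl gives an at least 6.7-fold lower number from compound 1 to compound 4 (0.82 log units; beyond the scatter) and so brings a measurable number where the earlier chlorophenyl compound had none. Going by these compounds, compound 1 remains a limit and not a number, so the true size of that step stays unknown: the limit of > 10000 nM in this assay, at which 1 of the 4 values shown sits. The gain is only partial, since replacing 4-nitrophenyl with 3-chlorophenyl gives a 19-fold higher number from compound 3 to compound 4 (1.28 log units; beyond the scatter) and replacing 3-hydroxy-4-methoxyphenyl with 3-chlorophenyl gives a 34-fold higher number from compound 2 to compound 4 (1.53 log units; beyond the scatter), which shows that, although the two earlier measured groups could not be told apart, the pendant group here can still separate compounds well beyond the scatter even once the 2-chlorophenyl group is gone.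

The compounds shown leave open how 4-chlorophenyl would compare with the two chlorophenyl groups, and so whether the trend with the place of the chlorine continues. They also leave open whether 3-hydroxyphenyl or 4-methoxyphenyl alone, or an amine or a carboxylic acid on the pendant ring, would match the two best groups seen here.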